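The source may hold more compounds than are shown below. What is called first, only, known or untested is meant among the compounds shown, and "the series" means these compounds.

Measured so far in an ADME assay on microsomes from liver (Homo sapiens) for metabolic stability, with a stated time of 10 min; a lower number here means that less of the compound is left, a higher number that more of the compound is left:
- Compound 1 `CC[C@]1(C(=O)O)CC[C@H](C(=O)N2CC[C@](c3ccc(C(F)(C(F)(F)F)C(F)(F)F)cc3)(S(=O)(=O)c3ccc(F)cc3)C2)CC1`: 100%
- Compound 2 `CCC[C@]1(C(=O)N2CC[C@](c3ccc(C(F)(C(F)(F)F)C(F)(F)F)cc3)(S(=O)(=O)c3ccc(F)cc3)C2)CC[C@H](C(=O)O)CC1`: "not determined" (no result reported)

For the measured compounds named here, compound 1, at 100%, holds the only number available, so it cannot be ranked against anything. Going by the values given here, compound 2 has no result to compare it with, and no measured step between two compounds offers a guide.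

The next compound is compound 3 `COC[C@]1(C(=O)N2CC[C@](c3ccc(C(F)(C(F)(F)F)C(F)(F)F)cc3)(S(=O)(=O)c3ccc(F)cc3)C2)CC[C@H](C(=O)O)CC1`, not yet measured in this assay. It carries 4-carboxy-1-(methoxymethyl)cyclohexyl in place of 4-carboxy-4-ethylcyclohexyl on a carbonyl carbon, while the rest of the core of compound 1 stays the same: 4-carboxy-1-(methoxymethyl)cyclohexyl in place of 4-carboxy-4-ethylcyclohexyl on a carbonyl carbon.

Compound 1 at 100% leaves little room for a rise, so a small downward step is expected, quite possibly none beyond the scatter. The expected change is a number 8 percentage points lower from compound 1 to compound 3 (within the scatter). For compound 3 the estimate is 92%, with an expected range from 75% to 100%.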

Compound 3, percent of the compound remaining: 100%
Beside the measured number, compound 3's estimate is 8 percentage points below it, and the stated range covers the measured number.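

For the compounds shown here, measured in this assay, placing 4-carboxy-1-(methoxymethyl)cyclohexyl on the carbonyl carbon in place of 4-carboxy-4-ethylcyclohexyl gives no change at the digits printed from compound 1 to compound 3 (within the scatter) and provides the first readable comparison at this position. Going by these compounds alone, the entering group has one more oxygen and one more hydrogen-bond acceptor, yet this exchange produces no detectable loss of compound in this test, although both compounds sit at the top of the scale, where any further gain could not be seen. No available measurement explains this outcome.

Steps involving compound 2 cannot be read, so the effect of its longer chain on the shared core remains unknown. As far as these compounds go, it also remains open whether an amine or a hydroxymethyl group at this position would leave the result unchanged.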